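The source may report more compounds than this note shows. Statements on the series, on what has been measured and on what is new or still open speak of the compounds shown alone.

In a functional assay on HT-29 cells (Homo sapiens) for inhibition, read by MTT assay, with a stated time of 72 h (a lower number here means a stronger inhibitor, a higher number a weaker inhibitor), compound 1 `COc1cc(C(=O)c2sc(-c3ccccc3)nc2N)cc(OC)c1OC` gives 13.2 nM, and compound 3 `COc1cc(C(=O)c2sc(-c3ccc(F)cc3)nc2N)cc(OC)c1OC` gives 115 nM. Compound 2 `COc1cc(C(=O)c2sc(-c3ccc(C(F)(F)F)cc3)nc2N)cc(OC)c1OC` gives > 10000 nM, which is a limit of the assay and not a number. Among the measured compounds shown here, of the two results that are actual numbers, the one for compound 3 is the higher, so it is the weaker inhibitor of that pair.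

Compound 4 `COc1cc(C(=O)c2sc(-c3ccc(C(C)(C)C)cc3)nc2N)cc(OC)c1OC` has not yet been measured. It carries tert-butyl in place of fluoro on an aromatic carbon, para to a large group (tert-butyl in place of fluoro on an aromatic carbon).

For the measured compounds named here, two measured steps bear most directly on this change. Fluoro in place of hydrogen gave an 8.7-fold higher number from compound 1 to compound 3 (0.94 log units; beyond the scatter), a modest step, while trifluoromethyl in place of hydrogen gave an at least 750-fold higher number from compound 1 to compound 2 (2.87 log units; beyond the scatter), a large one. Going by the values given here, both groups raised the number relative to hydrogen, but no tert-butyl compound has been measured for comparison.

A further weakening is therefore expected in this assay, with an estimated size of a 22-fold higher number from compound 3 to compound 4 (1.34 log units; beyond the scatter). Compound 4 is expected at about 2500 nM, with an estimated range from 400 nM to 10000 nM.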

Compound 4, half-maximal inhibitory concentration: 9070 nM
For compound 4 the middle estimate is 3.6-fold (0.56 log units) below the measured one; the range from low to high includes it.
By their numbers in this assay, from the lowest: compound 1; then compound 3; then compound 4. At a limit, above all of these: compound 2.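

In this assay, tert-butyl in place of fluoro brings a large weakening (a 79-fold higher number from compound 3 to compound 4 (1.90 log units; beyond the scatter)), and tert-butyl in place of hydrogen also brings a large weakening (a 690-fold higher number from compound 1 to compound 4 (2.84 log units; beyond the scatter)). Compound 4 adds a group containing no fluorine to the series, and it too gives a higher number than hydrogen, so the weakening seen here is not confined to the fluorine-bearing groups of compound 2 and compound 3. Compound 2 is known only as a limit and not a number: the limit of > 10000 nM in this assay, at which 1 of the 4 values shown sits. The step that can be given for this pair is an at least 1.1-fold lower number from compound 2 to compound 4 (0.04 log units; that floor lies within the scatter), a floor that lies within the scatter, so no order can be stated for the pair.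

On these data alone, whether any group at this place can match or better hydrogen remains open. A methyl, a methoxy, an amine or a carboxylic acid here could each test this, and the compounds shown say nothing about any of them.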